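The source may report more compounds than this note shows. Statements on the series, on what has been measured and on what is new or still open speak of the compounds shown alone.

Compound 1 `COc1cccc(Nc2nc3nonc3nc2O)c1` gives 75400 nM in an assay on mitochondria from L6 cells (Rattus norvegicus) for activation, with a stated time of 90 min (a lower number here means that less compound is needed, a higher number that more compound is needed for the effect), and compound 2 `CCCCOc1cccc(Nc2nc3nonc3nc2O)c1` gives 2300 nM, a change of a 33-fold lower number from compound 1 to compound 2 (1.52 log units; beyond the scatter). Compound 2 therefore holds the lowest of the two numbers seen so far. Compound 3 `Oc1nc2nonc2nc1Nc1cccc(S(F)(F)(F)(F)F)c1` differs from compound 2 by a group of 6 heavy atoms (5 fluorine, 1 sulfur; no ring) in place of a group of 5 heavy atoms (4 carbon, 1 oxygen; no ring), on an aromatic carbon. Within the data shown here, the one measured step concerns only the chain on the oxygen, which is itself removed here, so it offers no direct guide; no step beyond the scatter is expected, with wide uncertainty. Compound 3 is estimated at 4000 nM, between 800 nM and 20000 nM, a step of a 1.7-fold higher number from compound 2 to compound 3 (0.24 log units; within the scatter).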

Compound 3, half-maximal effective concentration: 3700 nM
Compound 3: middle estimate off by 1.1-fold (0.03 log units), on the high side; measured number inside the range.
By their numbers in this assay, from the lowest: compounds 2 and 3 (each within the scatter of the next); then compound 1.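

On this aromatic carbon, the butoxy group can be swapped for the group of five fluorines and one sulfur with a 1.6-fold higher number from compound 2 to compound 3 (0.21 log units; within the scatter), so the two compounds cannot be told apart in this assay. Set against compound 1, the same group gives a 20-fold lower number from compound 1 to compound 3 (1.31 log units; beyond the scatter). A low number here therefore does not need an oxygen on the ring or a carbon chain.

No measurement shown explains why such different groups give matching numbers. From the compounds shown here alone, whether a trifluoromethyl group or a chain longer than butoxy would do the same at this carbon stays open.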